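The source may hold more compounds than are shown below. What is called first, only, known or untested is meant among the compounds shown, and "the series" means these compounds.

In a functional assay on NCI-H460 cells (Homo sapiens) for inhibition, read by MTT assay, with a stated time of 72 h (a lower number here means a stronger inhibitor, a higher number a weaker inhibitor), compound 1 `COc1cc(NC(C)CCCNC(=O)Nc2ccc(C(F)(F)F)cc2)c2ncccc2c1` gives 24000 nM. Compound 2 `COc1cc(NC(C)CCCNC(=O)NNC(=O)Nc2cccc(C(F)(F)F)c2)c2ncccc2c1` gives 20000 nM in this assay. Compound 3 `COc1cc(NC(C)CCCNC(=O)NNC(=O)Nc2ccc(F)cc2)c2ncccc2c1` reaches only the limit of > 100000 nM in this assay, so for compound 3 a limit and not a number is known. Compound 3 thus stands at the weak end of the three, with an at least 4.1-fold higher number from compound 1 to compound 3 (0.61 log units; beyond the scatter) and an at least 5.0-fold higher number from compound 2 to compound 3 (0.69 log units; beyond the scatter), both beyond the scatter.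

Compound 4 `COc1cc(NC(C)CCCNC(=O)Nc2ccc(Cl)cc2)c2ncccc2c1` has not yet been measured in this assay. It differs from compound 3 by 4-chlorophenyl in place of ((4-fluorophenyl)carbamoyl)amino on an amide-type nitrogen. This change undoes the kind of change seen from compound 1 to compound 3, where an aryl group on the amide-type nitrogen gave way to the ((4-fluorophenyl)carbamoyl)amino group and the number rose by an at least 4.1-fold higher number from compound 1 to compound 3 (0.61 log units; beyond the scatter). The step of an at least 5.0-fold higher number from compound 2 to compound 3 (0.69 log units; beyond the scatter) points the same way. Since compound 3 rests at the limit of > 100000 nM in this assay, at which 1 of the 3 values shown sits, the size of any return can only be stated as a bound. Compound 4, carrying a 4-chlorophenyl group on that nitrogen as compound 1 carries a 4-(trifluoromethyl)phenyl group, is expected to fall back toward compound 1 by a step of an at least 4.0-fold lower number from compound 3 to compound 4 (0.60 log units; beyond the scatter). Compound 4 is estimated at 25000 nM, within 8000 nM to 80000 nM.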

Compound 4, half-maximal inhibitory concentration: 34000 nM
The estimate for compound 4 lay 1.4-fold (0.13 log units) below the measured number; the measured number falls inside the stated range.
By their numbers in this assay, from the lowest: compounds 2, 1 and 4 (each within the scatter of the next). At a limit, above all of these: compound 3.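

In this assay, putting 4-chlorophenyl on the amide-type nitrogen in place of ((4-fluorophenyl)carbamoyl)amino gives an at least 2.9-fold lower number from compound 3 to compound 4 (0.46 log units; beyond the scatter) and so turns a limit into a measured number at this place. As far as these compounds go, the true size of this step stays unknown, as one end of it is a limit and gives only a bound: the limit of > 100000 nM in this assay, at which 1 of the 4 values shown sits. For the compounds shown here, the other new step, a 1.4-fold higher number from compound 1 to compound 4 (0.15 log units; within the scatter), shows that chloro and trifluoromethyl on the aromatic carbon cannot be told apart here, which is the first direct comparison of two aryl groups on this shorter urea.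

From the compounds shown here alone, compound 2 carries the longer carbamoyl-bearing unit and still gives 20000 nM, so it goes against any reading that this unit alone costs activity, and whether the loss in compound 3 lies with the unit or with its 4-fluorophenyl group stays open. Also open, going by these compounds, is how the number would respond to an amine or a carboxylic acid on the aromatic ring, or to a longer chain between the shared core and the urea.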